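Chloro for methyl on two amide-linked cores

The source may hold more compounds than are shown below. What is called first, only, known or untested is meant among the compounds shown, and "the series" means these compounds.

Compounds 1 and 2 share one core, compounds 3 and 4 another; the difference between the two cores is not broken down here. Compound 1 `COc1cc2oc(-c3ccc(NC(=O)c4ccc(C)cc4)cc3)cc(=O)c2c(OC)c1OC` is measured in a functional assay on RPMI-8226 cells (Homo sapiens) for inhibition, read by sulforhodamine B assay, tested at 10 uM; a lower number here means less inhibition, a higher number more inhibition at the concentration tested (going by the name of the read-out). In this assay compound 1 reaches only a limit, <= 42.6%. Compound 2 `COc1cc2oc(-c3ccc(NC(=O)c4ccc(Cl)cc4)cc3)cc(=O)c2c(OC)c1OC` differs by chloro in place of methyl on an aromatic carbon. In this assay compound 2 likewise returns a limit, <= 42.6%. The step that the two limits leave unreadable from compound 1 to compound 2 rests on the limit of <= 42.6% in this assay, at which 2 of the 3 values shown sit, and therefore gives no readable size. Compound 3 `COc1cc2oc(-c3cccc(C(=O)Nc4ccc(C)cc4)c3)cc(=O)c2c(O)c1OC` gives 82.6% in this assay. Compound 4 `COc1cc2oc(-c3cccc(C(=O)Nc4ccc(Cl)cc4)c3)cc(=O)c2c(O)c1OC` carries the same change, (chloro in place of methyl on an aromatic carbon). With the earlier step unreadable, the expected step of a number 6.6 percentage points lower from compound 3 to compound 4 (within the scatter) is taken as small, resting on compound 3 at 82.6% alone. Compound 4 is expected to give about 76%, estimated between 45% and 95%.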

Compound 4, a percentage reported as inhibition, at one concentration (the size of the read-out at that concentration, not a potency): 82.6%
Compound 4: middle estimate off by 6.6 percentage points, on the low side, within the range that was stated.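

In this assay, chloro in place of methyl on an aromatic carbon of the core of compound 3 gives no change at the digits printed from compound 3 to compound 4 (within the scatter). This is one readable pair, tested at a single concentration in one cell line, so it shows that the two groups match on this core but says nothing about potency. From the compounds shown here alone, on the core of compound 1 the same change cannot be read, so carrying it from one core to the other remains untested: the limit of <= 42.6% in this assay, at which 2 of the 4 values shown sit.

Still open, going by these compounds, is whether an amine, a carboxylic acid or a longer alkyl chain at this position would match methyl and chloro on the core of compound 3. Also open, on these data alone, is how either core would respond to such groups at other concentrations.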